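A 1H-pyrazol-1-yl group enters compound 2

The compounds below may be only part of what the source reports. "The series", "measured", "known", "first", "only" and "open" are said of these compounds alone.

Measured in a physicochemical assay for lipophilicity, read by HPLC, measured as chromatographic lipophilicity, at pH 7.4; a higher number here means a more lipophilic compound, a lower number a more polar compound:
- compound 1 `COc1cccc(NC(=O)c2nnn(Cc3ccncc3)c2N)c1`: 1.4
- compound 2 `COc1cccc(NC(=O)c2nnn(Cc3ccc([S+](C)[O-])cc3)c2N)c1`: 1.3
- compound 3 `COc1cccc(NC(=O)c2nnn(C(C)c3ccc(C(C)(C)C)cc3)c2N)c1`: 3.9

Compound 2 sits level with compound 1 within the scatter, and far under compound 3 on the numbers of this assay. Compound 4 `COc1cccc(NC(=O)c2nnn(Cc3ccc(-n4cccn4)cc3)c2N)c1` differs from compound 2 as follows: a group of 5 heavy atoms (3 carbon, 2 nitrogen; one five-membered aromatic ring with 2 hetero atoms) in place of a group of 3 heavy atoms (1 carbon, 1 oxygen, 1 sulfur; no ring), on an aromatic carbon. Within the data shown here, only one measured step bears on this change, and only loosely: a number 0.10 log units lower from compound 1 to compound 2 (within the scatter). It leaves the size of the new step open. Compound 3, at 3.9, shows how far the series reaches, though it differs from compound 2 in more than one place. A moderate upward move is therefore expected, a number 1.40 log units higher from compound 2 to compound 4 (beyond the scatter). For compound 4 the estimate is 2.7, with an expected range of 2.1 to 3.3.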

Compound 4, distribution coefficient: 2.4
Estimate against measurement, compound 4: 0.30 log units above; measured number inside the range.
By their numbers in this assay, from the lowest: compounds 2 and 1 (each within the scatter of the next); then compound 4; then compound 3.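

In this assay the entry of 1H-pyrazol-1-yl on this aromatic carbon, para to a large group, gives a number 1.10 log units higher from compound 2 to compound 4 (beyond the scatter) and so shows that the number responds to the group held at this position, which the earlier step, within the scatter, did not show. Nothing shown gives a reason for the size of this step.

Going by these compounds, whether an amine, a carboxylic acid or a longer chain at this position would raise or lower the number remains open, as does whether the step holds on a different core.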